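Changing the anilide aryl group of a bis-benzylidene piperidinone

The source may report more compounds than this note shows. Statements on the series, on what has been measured and on what is new or still open speak of the compounds shown alone.

Measured compounds:
compound 1 `Cc1cccc(C)c1NC(=O)/C=C/C(=O)N1C/C(=C\c2ccccc2)C(=O)/C(=C/c2ccccc2)C1` — 7400 nM
compound 2 `CC(=O)c1ccc(NC(=O)/C=C/C(=O)N2C/C(=C\c3ccc([N+](=O)[O-])cc3)C(=O)/C(=C/c3ccc([N+](=O)[O-])cc3)C2)cc1` — 360 nM
compound 3 `Cc1ccc(NC(=O)/C=C/C(=O)N2C/C(=C\c3ccc([N+](=O)[O-])cc3)C(=O)/C(=C/c3ccc([N+](=O)[O-])cc3)C2)cc1C` — 700 nM

In a functional assay on CCRF-CEM cells (Homo sapiens) for cytotoxicity (a higher number here means a weaker inhibitor, a lower number a stronger inhibitor), compound 1 shows the highest number of the three, with compound 3 and compound 2 both giving lower numbers. Compound 4 `COc1ccc(NC(=O)/C=C/C(=O)N2C/C(=C\c3ccccc3)C(=O)/C(=C/c3ccccc3)C2)cc1` is compound 1 with one change: 4-methoxyphenyl in place of 2,6-dimethylphenyl on an amide-type nitrogen. Going by the values given here, no measured pair differs in exactly this way. Among the compounds with values here, the only measured step, a 1.9-fold higher number from compound 2 to compound 3 (0.29 log units; within the scatter), exchanges one aryl group on the same amide-type nitrogen for another, but within a different core, and it stays inside the scatter. On that basis no step beyond the scatter is expected for compound 4, and its estimate is 5500 nM (range 1800 nM to 17000 nM), which means a step of a 1.3-fold lower number from compound 1 to compound 4 (0.13 log units; within the scatter).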

Compound 4, half-maximal inhibitory concentration: 510 nM
Compound 4: the middle estimate sits 11-fold (1.03 log units) above what was measured, outside the stated range (below it).
By their numbers in this assay, from the lowest: compounds 2, 4 and 3 (each within the scatter of the next); then compound 1.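

In this assay, the aryl group on this amide-type nitrogen can matter a great deal: on the core of compound 1, the exchange gives a 15-fold lower number from compound 1 to compound 4 (1.16 log units; beyond the scatter). Going by these compounds alone, the only earlier aryl exchange, on a different core, gave a 1.9-fold higher number from compound 2 to compound 3 (0.29 log units; within the scatter). Nothing measured here explains the larger step.

The compounds shown do not separate the loss of the two methyl groups from the gain of the methoxy group, which a plain phenyl group on the same nitrogen could help resolve. Going by these compounds, whether this exchange has a similar effect on the core of compound 2 also remains open.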